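The source may report more compounds than this note shows. Statements on the series, on what has been measured and on what is new or still open speak of the compounds shown alone.

Measured compounds: compound 1, `Cc1ccc2nc(N3CCCc4ccc(F)cc4C3)cc(NCC(C)N)c2c1`, with 86000 nM in an ADME assay on HEp-2 cells (Homo sapiens) for cytotoxicity, read by CCK-8 assay, with a stated time of 5 days; a higher number here means that more compound is tolerated, a lower number that less compound is tolerated; compound 2, `Cc1ccc2nc(N3CCCc4ccc(F)cc4C3)cc(NC(=O)CN)c2c1`.

In this assay compound 2 gives only a limit, > 100000 nM. Within the data shown here, the one measured step, an at least 1.1-fold higher number from compound 1 to compound 2 (0.06 log units; that floor lies within the scatter), rests on that limit, as noted in the limit of > 100000 nM in this assay, at which 1 of the 2 values shown sits. The unmeasured compound 3, `Cc1ccc2nc(N3CCCc4ccc(F)cc4C3)cc(NCCNC3COC3)c2c1`, differs from compound 2 by 2-((oxetan-3-yl)amino)ethyl in place of (aminomethyl)carbonyl on a nitrogen on an aromatic ring. Among the measured compounds shown here, no measured step bears directly on this change, and the single step available is confined within the scatter, so no shift beyond the scatter is expected in this assay; compound 3 is estimated at 80000 nM, ranging from 30000 nM to 200000 nM. The step this implies, an at least 1.2-fold lower number from compound 2 to compound 3 (0.09 log units; that floor lies within the scatter), is an expectation only.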

Compound 3, half-maximal cytotoxic concentration: > 100000 nM
Compound 3: a limit, no number (the forecaster's own chance of this, stated with the estimate: 45%); middle value at least 1.2-fold (0.09 log units) from the limit.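

In this assay compound 3, with 2-((oxetan-3-yl)amino)ethyl on a nitrogen on an aromatic ring, gives a limit and not a number, as compound 2 does. The one readable comparison is an at least 1.1-fold higher number from compound 1 to compound 3 (0.06 log units; that floor lies within the scatter), a floor only, so no shift beyond the scatter is shown. The step between the two compounds with limits cannot be read: the limit of > 100000 nM in this assay, at which 2 of the 3 values shown sit.

Still open, as far as these compounds go, is whether a carboxylic acid or a longer chain on this nitrogen would give a number rather than a limit in this assay.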